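Aryl sulfonate series: diethylcarbamoyl replacing amino

This account rests on a few compounds, and the source may have more. Where it says the series, first, only, none or still open, it means among the compounds named here.

Compound 1 `CS(=O)(=O)Oc1ccc(-c2cncn2C2CCN(C(=O)c3ccc(Cl)c(C(F)(F)F)c3)CC2)cc1` gives 1570 nM in an assay on HEK293 cells for antagonist activity at P2X purinoceptor 7 (Homo sapiens), read by fluorescence, with a stated time of 2 h; on this read-out higher numbers stand for weaker inhibition and lower numbers for stronger inhibition. Compound 2 `Nc1cccc(S(=O)(=O)Oc2ccc(-c3cncn3C3CCN(C(=O)c4ccc(Cl)c(C(F)(F)F)c4)CC3)cc2)c1` gives 565 nM in this assay, the lowest of the two numbers, the step of a 2.8-fold lower number from compound 1 to compound 2 (0.44 log units; beyond the scatter) lying beyond the scatter. Compound 3 `CCN(CC)C(=O)c1cccc(S(=O)(=O)Oc2ccc(-c3cncn3C3CCN(C(=O)c4ccc(Cl)c(C(F)(F)F)c4)CC3)cc2)c1` carries diethylcarbamoyl in place of amino on an aromatic carbon. Going by the values given here, the only measured step, from compound 1 to compound 2, concerns the group on the sulfonyl sulfur rather than a substituent on the ring that carries the amino group, so it bears on the present change only loosely. The expected step of a 1.1-fold higher number from compound 2 to compound 3 (0.03 log units; within the scatter) is therefore none beyond the scatter. Compound 3 is estimated at 600 nM, within 200 nM to 2000 nM.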

Compound 3, half-maximal inhibitory concentration: 202 nM
Beside the measured number, compound 3's estimate is 3.0-fold (0.47 log units) above it, within the range that was stated.
By their numbers in this assay, from the lowest: compound 3; then compound 2; then compound 1.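

Diethylcarbamoyl on this aromatic carbon, meta to a large group, gives a 2.8-fold lower number from compound 2 to compound 3 (0.45 log units; beyond the scatter) in this assay, so the amino group is not needed for activity here. Going by these compounds alone, this place also accepts a substituent of 7 heavy atoms where amino has 1, and the step is the first one read at this position rather than on the sulfonyl sulfur. No evidence at hand accounts for the step.

On these data alone, whether the carbonyl or the ethyl chains carry the gain remains open. A primary carboxamide, a dimethylcarbamoyl group or a carboxylic acid at this place would separate these.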